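Methyl for chloro on the benzyl ring of compound 3

This account rests on a few compounds, and the source may have more. Where it says the series, first, only, none or still open, it means among the compounds named here.

Compound 3 `CC(C)c1c(C(=O)N(C)Cc2cccc(Cl)c2)nn(-c2ccc(F)cc2)c1OC[C@@H](O)C[C@@H](O)CC(=O)O` is measured in an assay on microsomes from liver for inhibition of 3-hydroxy-3-methylglutaryl-coenzyme A reductase (Rattus norvegicus) (a higher number here means a weaker inhibitor, a lower number a stronger inhibitor), where compound 3 gives 8.3 nM. Among the three measured compounds this is the second highest number: compound 1 `CC(C)c1c(C(=O)N(C)Cc2ccccc2)nn(-c2ccc(F)cc2)c1OC[C@@H](O)C[C@@H](O)CC(=O)O` gives 5.2 nM, and compound 2 `Cc1ccccc1CNC(=O)c1nn(-c2ccc(F)cc2)c(OC[C@@H](O)C[C@@H](O)CC(=O)O)c1C(C)C` gives 17 nM. The step from compound 1 to compound 3 is small, a 1.6-fold higher number from compound 1 to compound 3 (0.20 log units; within the scatter), while compound 2 stands further off, as seen in a 2.0-fold lower number from compound 2 to compound 3 (0.31 log units; beyond the scatter) and in a 3.3-fold higher number from compound 1 to compound 2 (0.51 log units; beyond the scatter).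

Compound 4 `Cc1cccc(CN(C)C(=O)c2nn(-c3ccc(F)cc3)c(OC[C@@H](O)C[C@@H](O)CC(=O)O)c2C(C)C)c1` differs from compound 3 in one place: methyl in place of chloro on an aromatic carbon. The change sits on the same aromatic carbon at which compound 1 and compound 3 already differ, and that exchange of hydrogen for chloro stayed within the scatter. The other step that touches a methyl on this ring, from compound 1 to compound 2, also alters the amide nitrogen and cannot be separated into its parts. Only the comparison of compound 1 with compound 3 therefore bears on the step at hand, and it points to no movement beyond the scatter. The expected step from compound 3 to compound 4 is a 1.2-fold lower number from compound 3 to compound 4 (0.07 log units; within the scatter). Compound 4 is thus expected to give 7 nM in this assay, within a range from 3 nM to 16 nM.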

Compound 4, half-maximal inhibitory concentration: 37 nM
Estimate against measurement, compound 4: 5.3-fold (0.72 log units) below, and the stated range ends below it.
By their numbers in this assay, from the lowest: compounds 1 and 3 (each within the scatter of the next); then compound 2; then compound 4.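

At this position on the benzyl ring, hydrogen and chloro could not be told apart in this assay, but methyl separates from both, with a 4.5-fold higher number from compound 3 to compound 4 (0.65 log units; beyond the scatter) and a 7.1-fold higher number from compound 1 to compound 4 (0.85 log units; beyond the scatter). The result shows that this aromatic carbon is not indifferent to what it carries, and that one heavy atom exchanged for another, with no change in the counted donors, acceptors or charge, can still move the number beyond the scatter. The methyl(3-methylbenzyl)amino group also stands above the (2-methylbenzyl)amino group, with a 2.2-fold higher number from compound 2 to compound 4 (0.34 log units; beyond the scatter), although that step alters both the place of the ring methyl and the amide nitrogen, and nothing available accounts for the parting of chloro and methyl.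

As far as these compounds go, whether fluoro, methoxy or trifluoromethyl on this carbon would stay with chloro or move with methyl remains open. So does the effect of the ring methyl alone on the amide series, which a (2-methylbenzyl)(methyl)amino group would help to separate from the effect of the methyl on the amide nitrogen.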